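A few compounds are considered here, and "the series" means these few. Any claim that something is new, unique, unknown or untested is made for them only; others in the source may bear on it.

Working notes on the urea series sharing the core of compound 1.

Compound 1 `CN(C)CCCNc1nc(-c2ccc(NC(=O)Nc3ccc(Cl)cc3)cc2)nc2c(Cl)c(Cl)sc12` gives 230 nM in a functional assay on NCI-H460 cells (Homo sapiens) for cytotoxicity, read by MTT assay, with a stated time of 72 h; a lower number here means a stronger inhibitor, a higher number a weaker inhibitor. Compound 2 `CN(C)CCCNc1nc(-c2ccc(NC(=O)Nc3ccccc3Cl)cc2)nc2c(Cl)c(Cl)sc12` gives 490 nM in this assay, and compound 3 `Cc1ccc(NC(=O)Nc2ccc(-c3nc(NCCCN(C)C)c4sc(Cl)c(Cl)c4n3)cc2)cc1` gives 1110 nM. Compound 2 stands second of the three numbers, with compound 1 giving a 2.1-fold higher number from compound 1 to compound 2 (0.33 log units; beyond the scatter) and compound 3 a 2.3-fold higher number from compound 2 to compound 3 (0.36 log units; beyond the scatter); the remaining pair shows a 4.8-fold higher number from compound 1 to compound 3 (0.68 log units; beyond the scatter).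

Compound 4 `CN(C)CCNc1nc(-c2ccc(NC(=O)Nc3ccccc3Cl)cc2)nc2c(Cl)c(Cl)sc12` differs from compound 2 by dimethylamino in place of (dimethylamino)methyl on a saturated chain carbon, two bonds along the chain from a nitrogen on an aromatic ring, so the 3-(dimethylamino)propyl chain becomes a 2-(dimethylamino)ethyl chain while the urea aryl remains the 2-chlorophenyl of compound 2. For the measured compounds named here, none of the measured steps touches this chain: all three concern the aryl on the urea nitrogen, and each was modest in size. The effect of altering the chain is therefore untested in this set, and the prior expectation is a step no larger than those seen, in either direction, or none beyond the scatter.

On that basis compound 4 is expected to give 490 nM in this assay, within 200 nM to 1200 nM, which corresponds to an expected no change at the digits printed from compound 2 to compound 4 (within the scatter).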

Compound 4, half-maximal inhibitory concentration: 440 nM
Estimate against measurement, compound 4: 1.1-fold (0.05 log units) above; the measured number falls inside the stated range.
By their numbers in this assay, from the lowest: compounds 1, 4 and 2 (each within the scatter of the next, the first and the last beyond it); then compound 3.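

In this assay, the 2-(dimethylamino)ethyl chain in place of the 3-(dimethylamino)propyl chain gives a 1.1-fold lower number from compound 2 to compound 4 (0.05 log units; within the scatter) on the 2-chlorophenyl urea, so this assay does not tell the two chain lengths apart. For the compounds shown here, this is the first step away from the urea aryl, and unlike the three aryl steps, each of which lies beyond the scatter, it shows that the chain position accepts this particular swap without a measurable difference. The finding holds only for the 2-chlorophenyl urea, and no measured property is available to account for it.

Still open, from the compounds shown here alone, is whether a longer chain such as 4-(dimethylamino)butyl, or a piperidine, a morpholine or a primary amine in place of the dimethylamino, would stay as close to compound 2 as compound 4 does. Also open, going by these compounds, is whether the 2-(dimethylamino)ethyl chain would match the 3-(dimethylamino)propyl chain on the 4-chlorophenyl urea of compound 1 and the 4-methylphenyl urea of compound 3.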